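A few compounds are considered here, and "the series" means these few. Any claim that something is new, unique, unknown or untested is made for them only; others in the source may bear on it.

Measured so far:
- compound 1, `NS(=O)(=O)c1ccc2nc(N3N=C(c4ccc(Br)cc4)CC3c3ccc(Cl)cc3)sc2c1`: 14%
- compound 2, `Cc1ccc(C2CC(c3ccc(Cl)cc3)=NN2c2nc3ccc(S(N)(=O)=O)cc3s2)cc1`: 14%

Of the compounds shown here, two share one core and have been tested in a functional assay on the whole organism (strain Wistar) for inhibition, with Rattus norvegicus as the target, read by paw edema, with stated times of 1 h and 5 h, at a dose of 20 mg/kg by the oral route; on this read-out lower numbers stand for less inhibition and higher numbers for more inhibition at the one dose given (going by the name of the read-out). Compound 1 gives 14%. Where compound 1 carries a 4-chlorophenyl group, compound 2 carries a methylphenyl group, and in this assay compound 2 gives 14%. Compound 1 thus stands level with compound 2 at the digits shown, and no difference beyond the scatter separates them. Going by the values given here, no step between two measured compounds that differ in a single place is available, so nothing measured yet tells how much one exchange at this position moves the read-out.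

Compound 3, `NS(=O)(=O)c1ccc2nc(N3N=C(c4ccc(Br)cc4)CC3c3cccs3)sc2c1`, is not yet measured. It differs from compound 1 as follows: thiophen-2-yl in place of 4-chlorophenyl on a saturated ring carbon. Both measured compounds sit at the same low level, and the exchange of one aromatic ring for another at this position in compound 2 left the read-out unchanged. Compound 3 is therefore expected to stay near that level, with the step of a number 1 percentage points higher from compound 1 to compound 3 (within the scatter) estimated as none beyond the scatter. The estimate for compound 3 is 15%, within a range from 5% to 28%.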

Compound 3, a percentage reported as inhibition, in the whole organism at one dose (the size of the read-out at that dose, not a potency): 14%
For compound 3 the middle estimate is 1 percentage points above the measured one; measured number inside the range.
By their numbers in this assay, from the lowest: compounds 1, 2 and 3 (each within the scatter of the next).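

In this assay the exchange of 4-chlorophenyl for thiophen-2-yl on a saturated ring carbon gives no change at the digits printed from compound 1 to compound 3 (within the scatter) and is the first step shown between two compounds that differ in one place only. At this position a five-membered aromatic ring with one hetero atom can therefore take the place of a six-membered aromatic ring of carbon only, with no change in the read-out beyond the scatter. Nothing measured here offers a reason for this result.

Going by these compounds, all three compounds carry an aromatic ring at this position, so it remains open whether an amine, a carboxylic acid or a longer chain there would move the read-out. On these data alone, it also remains open whether a single exchange at the 4-bromophenyl group would change the read-out.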